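Fluoro for methoxy on the aryl acid of compound 3

This account rests on a few compounds, and the source may have more. Where it says the series, first, only, none or still open, it means among the compounds named here.

Compound 1 `Cc1cn([C@H]2CCCN([C@H](CC(C)C)c3ccc(C(=O)O)c(Oc4cccc(Cl)c4)c3F)C2)c(=O)[nH]c1=O`: 0.92
Compound 2 `Cc1cn([C@H]2CCCN([C@@H](CC(C)C)c3ccc(C(=O)O)c(Oc4cccc(Cl)c4)c3F)C2)c(=O)[nH]c1=O`: 0.57
Compound 3 `COc1c(CN2CCC[C@H](n3cc(C)c(=O)[nH]c3=O)C2)ccc(C(=O)O)c1Oc1cccc(Cl)c1`: -0.77

In a physicochemical assay for lipophilicity, using the shake flask method, in phosphate buffer, measured as octanol-water partition, at pH 7.4 (on this read-out lower numbers stand for lower lipophilicity and higher numbers for higher lipophilicity), compound 3 stands lowest of the three numbers, beyond the scatter from both compound 2 and compound 1. Compound 4 `Cc1cn([C@H]2CCCN(Cc3ccc(C(=O)O)c(Oc4cccc(Cl)c4)c3F)C2)c(=O)[nH]c1=O` differs from compound 3 by fluoro in place of methoxy on an aromatic carbon. Going by the values given here, the one measured step, a number 0.35 log units lower from compound 1 to compound 2 (beyond the scatter), rests on the fact that compounds 1 and 2 differ only in the configuration as drawn and concerns no exchange of groups, so it does not bear on this change. Among the compounds with values here, compounds 1 and 2 carry the fluoro too, but differ from compound 3 in more than one place; their values show only that both fluoro-bearing members sit higher than compound 3. A small rise is expected, a number 0.27 log units higher from compound 3 to compound 4 (within the scatter), not surely beyond the scatter. Compound 4 is estimated at -0.5, from -1.1 to 0.1.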

Compound 4, distribution coefficient: -0.59
Estimate against measurement, compound 4: 0.09 log units above; the measured number falls inside the stated range.
By their numbers in this assay, from the lowest: compounds 3 and 4 (each within the scatter of the next); then compound 2; then compound 1.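

In this assay, fluoro in place of methoxy on the aromatic carbon ortho to a 3-chlorophenoxy group gives a number 0.18 log units higher from compound 3 to compound 4 (within the scatter) and so does not separate the two groups at this position. Hydrogen in place of isobutyl on the saturated chain carbon gives a number 1.16 log units lower from compound 2 to compound 4 (beyond the scatter) and a number 1.51 log units lower from compound 1 to compound 4 (beyond the scatter) with the fluoro kept, so the large differences in this set go with that exchange, not with the one on the aromatic carbon. Nothing at hand gives a cause for any of these steps.

From the compounds shown here alone, whether an amine or a nitrile at the same aromatic carbon would also stay within the scatter of compound 3 remains open. So does the size of the step for a methyl in place of the isobutyl.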